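Series notes: nitro for fluoro, compound 1 to compound 4

The source may hold more compounds than are shown below. What is called first, only, known or untested is meant among the compounds shown, and "the series" means these compounds.

Measured compounds:
compound 1 `O=C1C(=O)N(CCCCn2cc(COc3cc(=O)oc4ccccc34)nn2)c2ccc(F)cc21` — 77%
compound 2 `O=C1C(=O)N(CCCCCn2cc(COc3cc(=O)oc4ccccc34)nn2)c2ccc(Br)cc21` — 52%
compound 3 `COc1ccc2c(c1)C(=O)C(=O)N2CCCn1cc(COc2cc(=O)oc3ccccc23)nn1` — 56%

In a functional assay on THP-1 cells (Homo sapiens) for inhibition, read by sulforhodamine B assay, with a stated time of 48 h, tested at 50 uM (a higher number here means more inhibition of growth at the concentration tested, a lower number less inhibition of growth), compound 1 gives 77%. Compound 2 gives 52% and compound 3 gives 56%. Compound 1 stands highest of the three numbers; the nearest number, that of compound 3, lies lower by a margin beyond the scatter, and the furthest, that of compound 2, lies lower still, also beyond the scatter. Compounds 2 and 3 each differ from compound 1 in more than one place, so their values show only where they stand, not what any single change does.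

Compound 4 `O=C1C(=O)N(CCCCn2cc(COc3cc(=O)oc4ccccc34)nn2)c2ccc([N+](=O)[O-])cc21` has not been measured. It differs from compound 1 by nitro in place of fluoro on an aromatic carbon. Among the compounds with values here, no single-change step between measured compounds is known, so nothing here shows what a change at that position does on its own. The expectation is a small step, a number 7 percentage points lower from compound 1 to compound 4 (within the scatter), downward if anything, not clearly beyond the scatter. Compound 4 is expected to give 70%, with a range from 50% to 88%.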

Compound 4, percent growth inhibition at one concentration: 55%
Compound 4: middle estimate off by 15 percentage points, on the high side, within the range that was stated.
By their numbers in this assay, from the lowest: compounds 2, 4 and 3 (each within the scatter of the next); then compound 1.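

Nitro in place of fluoro on the aromatic carbon provides the first single-change step in the series: in this assay, the change gives a number 22 percentage points lower from compound 1 to compound 4 (beyond the scatter). The earlier compounds shown here could not show this, as each differed from compound 1 in more than one place; this position of the shared core now proves sensitive to the group it carries, at least for this pair. No evidence at hand bears on what lies behind the step.

A single step does not show whether other groups on this carbon would keep the number of compound 1 or lower it, and an amine or a carboxylic acid there would test that. Going by these compounds, whether the same step would appear with a different chain on the ring nitrogen also remains open.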